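The source may report more compounds than this note shows. Statements on the series, on what has been measured and on what is new or still open speak of the compounds shown alone.

In a functional assay on NB-4 cells (Homo sapiens) for inhibition, read by XTT assay, with a stated time of 48 h (on this read-out higher numbers stand for weaker inhibition and lower numbers for stronger inhibition), compound 1, with the structure `COc1ccc(C(=O)/C(=C/c2ccccc2Cl)COC(=O)c2ccccc2)cc1`, gives 7000 nM. Compound 2, with the structure `C=C(C/C(=C\c1ccc(OC(=O)c2ccccc2)cc1)C(=O)c1ccc(OC)cc1)C(=O)c1ccc(OC)cc1`, gives 6700 nM in this assay. Compound 3, with the structure `C=C(C/C(=C\c1ccccc1)C(=O)c1ccc(OC)cc1)C(=O)c1ccc(OC)cc1`, gives 7400 nM in this assay. Of the three numbers that of compound 3 is the highest, yet it sits within the usual scatter of both others, so no order among compounds 1, 2 and 3 can be read from these figures. Among the measured compounds shown here, the one measured step, a 1.1-fold higher number from compound 2 to compound 3 (0.04 log units; within the scatter), changes a group on the same aromatic carbon that matters here and leaves the number essentially where it was.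

Compound 4, with the structure `C=C(C/C(=C\c1ccc(C)cc1)C(=O)c1ccc(OC)cc1)C(=O)c1ccc(OC)cc1`, differs from compound 3 by methyl in place of hydrogen on an aromatic carbon. For the measured compounds named here, the only step that bears on this change is the one from compound 2 to compound 3, which also altered what sits on that aromatic carbon, para to a large group, and stayed within the scatter. On that basis the methyl is expected to move the number little, if at all, in this assay. The step of a 1.1-fold lower number from compound 3 to compound 4 (0.02 log units; within the scatter) is therefore the expected outcome, with no direction claimed beyond the scatter. Compound 4 is accordingly estimated at 7000 nM, with a range from 3000 nM to 16000 nM.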

Compound 4, half-maximal inhibitory concentration: 11400 nM
Compound 4: the middle estimate sits 1.6-fold (0.21 log units) below what was measured, and the stated range covers the measured number.
By their numbers in this assay, from the lowest: compounds 2, 1, 3 and 4 (each within the scatter of the next).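

Compound 4 brings a new kind of group to the aromatic carbon para to a large group: phenyl becomes 4-methylphenyl, and in this assay this gives a 1.5-fold higher number from compound 3 to compound 4 (0.19 log units; within the scatter) for the addition of a single carbon. Replacing the much larger benzoyloxy group on that same carbon with methyl gives a 1.7-fold higher number from compound 2 to compound 4 (0.23 log units; within the scatter) and so also fails to separate the two compounds. Hydrogen, methyl and benzoyloxy have now all been compared at this position, and every step among them lies within the scatter, so compounds 2, 3 and 4 show no measurable preference among these three groups, a broader statement than the single comparison of hydrogen with benzoyloxy could support.

Still open, going by these compounds, is whether a group of another kind on this carbon, such as an amine, a carboxylic acid, a fluorine atom or a longer chain, would move the number beyond the scatter. Nothing available here offers an explanation for why these three compounds give such similar numbers.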